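The compounds below may be only part of what the source reports. "The series", "measured", "known", "first", "only" and "open" are said of these compounds alone.

The three compounds measured so far, each with its result in an ADME assay on the whole organism with Oryza sativa as the target, tested at 10 uM; a lower number here means a stronger effect, a higher number a weaker effect of the compound at the concentration tested:

compound 1, `C[C@@H](NC(=O)Nc1ccccc1C(F)(F)F)c1ccccc1`, for which compound 1 gives 54%
compound 2, `C[C@H](NC(=O)Nc1ccccc1C(F)(F)F)c1ccccc1`, for which compound 2 gives 97%
compound 3, `C[C@@H](NC(=O)Nc1cccc(Cl)c1)c1ccccc1`, for which compound 3 gives 83%

Among these numbers compound 2 stands highest, the weakest effect of the three. Its nearest neighbour is compound 3, and the furthest is compound 1, from which it differs only in the configuration as drawn: a number 43 percentage points higher from compound 1 to compound 2 (beyond the scatter). That step rests on (the fact that compounds 1 and 2 differ only in the configuration as drawn).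

The next compound, compound 4, `C[C@H](NC(=O)Nc1ccccc1Br)c1ccccc1`, is reached from compound 2 by a single change: bromo in place of trifluoromethyl on an aromatic carbon. Among the compounds with values here, no measured step describes such a swap of one group for another at this place; the only step known is the configuration change from compound 1 to compound 2, which says nothing about a bromo in place of a trifluoromethyl. Compound 3 carries a chloro, but at another position and on another backbone configuration, so its value alone cannot be turned into a prediction for the exchange at hand.

With nothing to point elsewhere, the expected step in this assay is small, none beyond the scatter: the expectation is a number 7 percentage points lower from compound 2 to compound 4 (within the scatter). Compound 4 is therefore estimated to give about 90%, between 68% and 100%.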

Compound 4, a percentage reported as activity, at one concentration (the size of the read-out at that concentration, not a potency): 102%
Estimate against measurement, compound 4: 12 percentage points below; the measured number lies above the stated range.
By their numbers in this assay, from the lowest: compound 1; then compound 3; then compounds 2 and 4 (each within the scatter of the next).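

In this assay, putting bromo in place of trifluoromethyl on an aromatic carbon, ortho to a large group, gives a number 5 percentage points higher from compound 2 to compound 4 (within the scatter), so with this configuration the assay does not tell the two groups apart. Within the data shown here, this is the first reading of a swap of one group for another at this place, and it shows that a group of 4 heavy atoms can give way to a single bromine without a step beyond the scatter. Both numbers are high, however, and with compound 4 at 102% the pair shows little effect of either group, while no measurement at hand explains why the two match.

Going by these compounds, the configuration of compound 1 gives a much lower number, as a number 43 percentage points higher from compound 1 to compound 2 (beyond the scatter) shows, and whether bromo would match trifluoromethyl on that configuration as well stays open. Also open, on these data alone, is what an amine, a carboxylic acid or a longer chain at this place would give on either configuration.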